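This account rests on a few compounds, and the source may have more. Where it says the series, first, only, none or still open, it means among the compounds named here.

Compound 1 `COc1ccc(/C=C2/SC(N3CCC[C@H]3C(=O)Nc3ccc4ncnc(Nc5cccc(Cl)c5)c4c3)=NC2=O)cc1` belongs to a set of three compounds that share one core and differ only in the aryl group on a double-bonded chain carbon bound to a double-bonded ring carbon. In a functional assay on HepG2 cells (Homo sapiens) for antiproliferative activity, read by MTT assay (on this read-out lower numbers stand for stronger inhibition and higher numbers for weaker inhibition), compound 1 gives 19000 nM, the second highest of the three numbers. Compound 2 `O=C1N=C(N2CCC[C@H]2C(=O)Nc2ccc3ncnc(Nc4cccc(Cl)c4)c3c2)S/C1=C/c1cccs1` gives 4120 nM in this assay, and compound 3 `O=C1N=C(N2CCC[C@H]2C(=O)Nc2ccc3ncnc(Nc4cccc(Cl)c4)c3c2)S/C1=C/c1ccccc1Br` gives 24300 nM. Among the measured steps, a 4.6-fold lower number from compound 1 to compound 2 (0.66 log units; beyond the scatter) and a 5.9-fold higher number from compound 2 to compound 3 (0.77 log units; beyond the scatter), whereas a 1.3-fold higher number from compound 1 to compound 3 (0.11 log units; within the scatter). Compound 4 `COc1ccccc1/C=C1/SC(N2CCC[C@H]2C(=O)Nc2ccc3ncnc(Nc4cccc(Cl)c4)c3c2)=NC1=O` is built from compound 1 from the same atoms joined differently: 2-methoxyphenyl in place of 4-methoxyphenyl on a double-bonded chain carbon bound to a double-bonded ring carbon. Going by the values given here, the step that bears most on this change is the one to compound 3, where 2-bromophenyl replaced 4-methoxyphenyl at the same place and the number hardly moved. On that basis compound 4 is expected to show only a small step, a 1.1-fold higher number from compound 1 to compound 4 (0.02 log units; within the scatter), with no clear direction beyond the scatter. Compound 4 is therefore estimated to give about 20000 nM in this assay, within a range of 8000 nM to 50000 nM.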

Compound 4, half-maximal inhibitory concentration: 22100 nM
Estimate against measurement, compound 4: 1.1-fold (0.04 log units) below, within the range that was stated.
By their numbers in this assay, from the lowest: compound 2; then compounds 1, 4 and 3 (each within the scatter of the next).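

In this assay, the new result shows that the site of the methoxy on the phenyl ring at this place makes no difference beyond the scatter (a 1.2-fold higher number from compound 1 to compound 4 (0.07 log units; within the scatter)). Methoxy in place of bromo on the aromatic carbon likewise gives no separable change (a 1.1-fold lower number from compound 3 to compound 4 (0.04 log units; within the scatter)), so compounds 1, 3 and 4 sit together, while the thiophen-2-yl of compound 2 remains apart from this group as well (a 5.4-fold higher number from compound 2 to compound 4 (0.73 log units; beyond the scatter)). Nothing available here accounts for this flat response among the three phenyl compounds or for the gap to compound 2.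

The compounds shown leave open whether the gap belongs to thiophen-2-yl alone or would also appear with a furyl or a pyridyl at this place. They also leave open whether an unsubstituted phenyl, or a phenyl carrying a dimethylamino group or a carboxylic acid, would move the number beyond the scatter.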